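Swapping the aryl group on a methylated indazole urea

A few compounds are considered here, and "the series" means these few. Any claim that something is new, unique, unknown or untested is made for them only; others in the source may bear on it.

Three urea compounds share a core built from an indazole and a pyrazole bearing a trifluoromethyl group, and they have been tested in an assay on CHO-K1 cells for antagonist activity at transient receptor potential cation channel subfamily V member 1 (Homo sapiens), read by FLIPR and calcium flux, with a stated time of 6 min; a lower number here means a stronger inhibitor, a higher number a weaker inhibitor. Compound 1 `O=C(NCc1cc(C(F)(F)F)nn1-c1ccc(F)c(Cl)c1)Nc1cccc2[nH]ncc12` gives 0.6 nM in this assay. Compound 2 `Cc1ccc(-n2nc(C(F)(F)F)cc2CNC(=O)Nc2cccc3[nH]ncc23)cc1C` carries 3,4-dimethylphenyl in place of 3-chloro-4-fluorophenyl on an aromatic nitrogen and gives 2.8 nM in this assay, so that the change produced a 4.7-fold higher number from compound 1 to compound 2 (0.67 log units; beyond the scatter). Compound 3 `Cn1ncc2c(NC(=O)NCc3cc(C(F)(F)F)nn3-c3ccc(F)c(Cl)c3)cccc21` differs from compound 1 by methyl in place of hydrogen on an aromatic nitrogen, and in this assay compound 3 gives 1.9 nM, a step of a 3.2-fold higher number from compound 1 to compound 3 (0.50 log units; beyond the scatter). Compound 2 and compound 3 sit within the usual scatter of each other, so no order between them can be read from these two numbers.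

Compound 4 `Cc1ccc(-n2nc(C(F)(F)F)cc2CNC(=O)Nc2cccc3c2cnn3C)cc1C` has not yet been measured. It differs from compound 3 by 3,4-dimethylphenyl in place of 3-chloro-4-fluorophenyl on an aromatic nitrogen, and the place where this swap happens is described in the same words as for the step from compound 1 to compound 2, so it is the same change applied to the methylated core instead. Within the data shown here, the one earlier instance is a 4.7-fold higher number from compound 1 to compound 2 (0.67 log units; beyond the scatter), which was beyond the scatter.

Among the measured compounds shown here, on that basis compound 4 is expected to show a step of about a 4.2-fold higher number from compound 3 to compound 4 (0.62 log units; beyond the scatter) in this assay, because the only comparable swap gave a 4.7-fold higher number from compound 1 to compound 2 (0.67 log units; beyond the scatter). The estimate for compound 4 is 8 nM, with a range from 3 nM to 25 nM, since a single example cannot tell whether the two changes add up exactly.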

Compound 4, inhibition constant: 3.5 nM
Compound 4: middle estimate off by 2.3-fold (0.36 log units), on the high side, within the range that was stated.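

In this assay, the aryl swap on the methylated core gives a 1.8-fold higher number from compound 3 to compound 4 (0.27 log units; within the scatter), and adding the methyl to the core that already carries 3,4-dimethylphenyl gives a 1.3-fold higher number from compound 2 to compound 4 (0.10 log units; within the scatter), so neither new step can be told apart from the ordinary variation between repeat measurements. Each step looks smaller than its earlier counterpart, but this does not show that the aryl swap really loses its effect on the methylated core, nor does it prove that the effect carries over unchanged; the data show only that the two instances cannot be separated: the same change on two cores in this assay, a 4.7-fold higher number (0.67 log units; beyond the scatter) from compound 1 to compound 2 and a 1.8-fold higher number (0.27 log units; within the scatter) from compound 3 to compound 4, 2.5-fold (0.40 log units) apart, within the scatter of two such steps. The methyl change leads to the same limited conclusion, with no measurable difference between its effects on the two cores, although a real difference of modest size could still be hidden in the variation: the same change on two cores in this assay, a 3.2-fold higher number (0.50 log units; beyond the scatter) from compound 1 to compound 3 and a 1.3-fold higher number (0.10 log units; within the scatter) from compound 2 to compound 4, 2.5-fold (0.40 log units) apart, within the scatter of two such steps.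

Among these compounds, each change is seen in just one pair of cores, with only two aryl groups and only hydrogen or methyl on the aromatic nitrogen, so a firm rule for combining the two changes remains open. Going by these compounds, it is also open whether the same picture would hold with an ethyl group on that nitrogen, or with a nitrile or a methoxy group on the phenyl ring.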